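Bromo removal on the shared core: tolerance notes

This account rests on a few compounds, and the source may have more. Where it says the series, first, only, none or still open, it means among the compounds named here.

Compound 1 `COc1ccc2c(OCC[C@@H]3NC(=O)N(C)CCCC/C=C\[C@@H]4C[C@@]4(C(=O)NS(=O)(=O)C4(C)CC4)NC3=O)cc(-c3nc(C(C)C)cs3)nc2c1Br` gives 28300 nM in an ADME assay on cells (Homo sapiens) for activation; a lower number here means that less compound is tolerated, a higher number that more compound is tolerated. Going by the values given here, compound 2 `COc1ccc2c(OCC[C@@H]3NC(=O)N(C)CCCC/C=C\[C@@H]4C[C@@]4(C(=O)NS(=O)(=O)C4(C)CC4)NC3=O)cc(-n3ccc(C(C)C)n3)nc2c1C` gives 25600 nM in this assay; the two numbers measured so far lie within the scatter of each other, so compound 1 cannot be set apart from compound 2. Compound 3 `COc1ccc2c(OCC[C@@H]3NC(=O)N(C)CCCC/C=C\[C@@H]4C[C@@]4(C(=O)NS(=O)(=O)C4(C)CC4)NC3=O)cc(-c3nc(C(C)C)cs3)nc2c1` is not yet measured. It differs from compound 1 as follows: hydrogen in place of bromo on an aromatic carbon. Among the compounds with values here, no measured pair fixes the size of this step, so the step of a 1.1-fold higher number from compound 1 to compound 3 (0.03 log units; within the scatter) is expected to stay within the scatter, with no clear direction. For compound 3 the estimate is 30000 nM, with a range from 14000 nM to 60000 nM.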

Compound 3, half-maximal cytotoxic concentration: 6500 nM
The estimate for compound 3 lay 4.6-fold (0.66 log units) above the measured number, and the stated range ends above it.
By their numbers in this assay, from the lowest: compound 3; then compounds 2 and 1 (each within the scatter of the next).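

The bromo on this aromatic carbon, ortho to a methoxy group, matters in this assay: hydrogen in its place gives a 4.4-fold lower number from compound 1 to compound 3 (0.64 log units; beyond the scatter) and so less compound is tolerated. This position is therefore not silent in the series, which the near-equal numbers of compound 1 and compound 2 could not reveal. Nothing measured here explains the step.

Open, from the compounds shown here alone, is whether the bromo is specifically required, or whether a chloro or fluoro on the same carbon would hold the number of compound 1. An amine there remains equally unresolved.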